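Moving the hydroxy group from compound 2 to compound 3

The compounds below may be only part of what the source reports. "The series", "measured", "known", "first", "only" and "open" are said of these compounds alone.

Compound 1 `O=C(Cc1csc2nc(-c3ccc(Br)cc3)cn12)N/N=C/c1ccccc1`: > 100000 nM (a limit)
Compound 2 `O=C(Cc1csc2nc(-c3ccc(Br)cc3)cn12)N/N=C/c1ccccc1O`: 19100 nM

Within the data shown here, in a functional assay on HT-29 cells (Homo sapiens) for inhibition, read by sulforhodamine B assay, with a stated time of 48 h (on this read-out higher numbers stand for weaker inhibition of growth and lower numbers for stronger inhibition of growth), compound 2 gives 19100 nM, the only exact number so far. Compound 3 `O=C(Cc1csc2nc(-c3ccc(Br)cc3)cn12)N/N=C/c1ccc(O)cc1` has 4-hydroxyphenyl in place of 2-hydroxyphenyl on a carbon with a double bond to nitrogen. Among the measured compounds shown here, one measured step bears on this: an at least 5.2-fold lower number from compound 1 to compound 2 (0.71 log units; beyond the scatter), with hydroxy in place of hydrogen on an aromatic carbon. One end of that step is the limit of > 100000 nM in this assay, at which 1 of the 2 values shown sits. Compound 3 keeps the hydroxy group of that step, so only a small shift towards a higher number is expected, probably within the scatter. The expected step is a 1.5-fold higher number from compound 2 to compound 3 (0.17 log units; within the scatter). Compound 3 is estimated at 28000 nM, with an expected range of 9000 nM to 90000 nM.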

Compound 3, concentration for total growth inhibition: > 100000 nM
Compound 3: only a limit was reported; the forecaster's own chance of this, stated with the estimate: 25%; middle value at least 3.5-fold (0.55 log units) away from the limit.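

Among these compounds, the earlier compounds showed only that compound 2, with its hydroxy group, gave a lower number than compound 1. In this assay, the hydroxy group alone proves not to be enough, as 4-hydroxyphenyl in place of 2-hydroxyphenyl gives an at least 5.2-fold higher number from compound 2 to compound 3 (0.71 log units; beyond the scatter), with the same atoms joined differently. The reading for compound 3 is a limit, the step between compound 1 and compound 3 cannot be read, and the size of the loss stays bounded on one side only: the limit of > 100000 nM in this assay, at which 2 of the 3 values shown sit.

The compounds shown leave open whether an amine or a methoxy group in place of the hydroxy of 2-hydroxyphenyl would keep a measurable number.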